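Compound 2 to compound 3: exchanging one aryl group

A few compounds are considered here, and "the series" means these few. Any claim that something is new, unique, unknown or untested is made for them only; others in the source may bear on it.

In a functional assay on a cell-free system (plasma, Homo sapiens), with a stated time of 3 min (a lower number here means a stronger inhibitor, a higher number a weaker inhibitor), compound 1 `O=C(NCc1cc(Cl)ccc1-n1cnnn1)[C@@H]1C[C@@H]2C[C@@H]2N1C(=O)[C@H](O)CC1CC1` gives 1700 nM. For the measured compounds named here, compound 2 `Cc1cccc([C@@H](O)C(=O)N2N=CC[C@H]2C(=O)NCc2cc(Cl)ccc2-n2cnnn2)c1` gives 830 nM, the lower of the two numbers so far, and its gap to compound 1 lies beyond the scatter. Going by the values given here, these two compounds differ in more than one place, so the series offers no measured single-change step.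

Compound 3 `O=C(NCc1cc(Cl)ccc1-n1cnnn1)[C@@H]1CC=NN1C(=O)[C@H](O)c1ccccc1F` keeps the rest of compound 2 and changes one group: 2-fluorophenyl in place of 3-methylphenyl on a saturated chain carbon bound to a carbonyl carbon and an oxygen on a saturated carbon. That is 2-fluorophenyl in place of 3-methylphenyl on a saturated chain carbon bound to a carbonyl carbon and an oxygen on a saturated carbon.

Among the compounds with values here, with no measured step to size this exchange, no shift beyond the scatter is expected. The expected outcome is a 1.2-fold higher number from compound 2 to compound 3 (0.08 log units; within the scatter), which is estimated to stay within the scatter. For compound 3 the estimated value in this assay is 1000 nM, with an expected range from 350 nM to 2800 nM.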

Compound 3, half-maximal inhibitory concentration: 1100 nM
Estimate against measurement, compound 3: 1.1-fold (0.04 log units) below; measured number inside the range.
By their numbers in this assay, from the lowest: compounds 2, 3 and 1 (each within the scatter of the next, the first and the last beyond it).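

In this assay, for the compounds shown here, 2-fluorophenyl in place of 3-methylphenyl on a saturated chain carbon bound to a carbonyl carbon and an oxygen on a saturated carbon gives a 1.3-fold higher number from compound 2 to compound 3 (0.12 log units; within the scatter), the first measured single-change step. At this position, the two aryl groups, which have the same heavy-atom count and no hydrogen-bond donors or acceptors, are not told apart by this read-out. No measured evidence bears on the size of this step.

A single aryl exchange leaves open how this position responds to a non-aryl group, such as an amine, a carboxylic acid or a longer chain. It also leaves open whether 2-fluorophenyl and 3-methylphenyl remain indistinguishable on a different core, such as the core of compound 1.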